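The source may hold more compounds than are shown below. What is called first, only, known or untested is meant among the compounds shown, and "the series" means these compounds.

Compound 2 `CC1(C)CO[C@H]1CN([C@H](CCC(F)(F)F)C(N)=O)S(=O)(=O)c1ccc(Cl)cc1` gives 26.4 10^-6 cm/s in an ADME assay on MDCKII-LE cells (Canis lupus familiaris) for permeability, read by transwell migration, in the apical to basolateral direction (a higher number here means that the compound crosses the layer faster, a lower number that the compound crosses the layer more slowly), the largest of the three numbers shown; compound 3 `NC(=O)[C@@H](CCC(F)(F)F)N(C[C@@H]1CCOC1)S(=O)(=O)c1ccc(Cl)cc1` with 20.5 10^-6 cm/s and compound 1 `CC1(C)C[C@H](CN([C@H](CCC(F)(F)F)C(N)=O)S(=O)(=O)c2ccc(Cl)cc2)O1` with 18.1 10^-6 cm/s both lie within the scatter of it. Compound 4 `NC(=O)[C@@H](CCC(F)(F)F)N(C[C@H]1CCCO1)S(=O)(=O)c1ccc(Cl)cc1` is not yet measured; it differs from compound 2 by oxolan-2-yl in place of 3,3-dimethyloxetan-2-yl on a saturated chain carbon bound to a sulfonamide nitrogen. The closest measured step is a 1.3-fold lower number from compound 2 to compound 3 (0.11 log units; within the scatter), a five-membered non-aromatic ring entering in place of the same 3,3-dimethyloxetan-2-yl. The steps of a 1.5-fold higher number from compound 1 to compound 2 (0.16 log units; within the scatter) and a 1.1-fold higher number from compound 1 to compound 3 (0.05 log units; within the scatter) likewise stay within the scatter, so the ring exchanges seen so far have not moved this assay. For compound 4 no step beyond the scatter is expected, a 1.2-fold lower number from compound 2 to compound 4 (0.08 log units; within the scatter). Compound 4 is therefore estimated at 22 10^-6 cm/s, with a range from 14 10^-6 cm/s to 34 10^-6 cm/s.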

Compound 4, apparent permeability: 19.1 10^-6 cm/s
Compound 4: the middle estimate sits 1.2-fold (0.06 log units) above what was measured, within the range that was stated.
By their numbers in this assay, from the lowest: compounds 1, 4, 3 and 2 (each within the scatter of the next).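

In this assay, oxolan-2-yl on a saturated chain carbon bound to a sulfonamide nitrogen stays level with both dimethyloxetan-2-yl groups (a 1.4-fold lower number from compound 2 to compound 4 (0.14 log units; within the scatter)) and (a 1.1-fold higher number from compound 1 to compound 4 (0.02 log units; within the scatter)). It also cannot be told apart from oxolan-3-yl (a 1.1-fold lower number from compound 3 to compound 4 (0.03 log units; within the scatter)), so this exchange of ring attachment, like the ring exchanges, leaves the number within the scatter. No supporting measurement bears on why these steps stay so small. From the compounds shown here alone, whether an amine or a carboxylic acid at this place would give a step beyond the scatter remains open. The same holds for a longer chain.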